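Moving the hydroxy group: compound 3 to compound 4

The compounds below may be only part of what the source reports. "The series", "measured", "known", "first", "only" and "open" are said of these compounds alone.

Compound 1, `CCOc1ccc(/C=N/NC(=O)COc2cccc3ccccc23)cc1O`: in an ADME assay on HEL cells (Homo sapiens) for cytotoxicity (a lower number here means that less compound is tolerated, a higher number that more compound is tolerated), compound 1 gives 100 ug/mL.
Compound 2, `O=C(COc1cccc2ccccc12)N/N=C/c1ccc(Cl)cc1`: compound 2 gives 100 ug/mL.
Compound 3, `O=C(COc1cccc2ccccc12)N/N=C/c1ccc(O)cc1`: compound 3 gives 20 ug/mL.

Compound 3 stands lowest of the three numbers; compound 1 and compound 2 share the same value, each beyond the scatter above compound 3. Within the data shown here, the only single-point step measured is a 5.0-fold lower number from compound 2 to compound 3 (0.70 log units; beyond the scatter), where hydroxy in place of chloro on an aromatic carbon lowered the number.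

Compound 4, `O=C(COc1cccc2ccccc12)N/N=C/c1cccc(O)c1`, differs from compound 3 by 3-hydroxyphenyl in place of 4-hydroxyphenyl on a carbon with a double bond to nitrogen. Among the measured compounds shown here, no measured step moves a group to another position on a ring, so that step gives no direct guide; the hydroxy group itself is kept. The change is therefore expected to stay within the scatter. Compound 4 is expected to give about 20 ug/mL, within 8 ug/mL to 60 ug/mL, meaning an expected step of no change at the digits printed from compound 3 to compound 4 (within the scatter).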

Compound 4, minimum cytotoxic concentration: 100 ug/mL
The estimate for compound 4 lay 5.0-fold (0.70 log units) below the measured number; the measured number lies above the stated range.
By their numbers in this assay, from the lowest: compound 3; then compounds 1, 2 and 4 (each within the scatter of the next).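

In this assay, moving the hydroxy group matters: 3-hydroxyphenyl in place of 4-hydroxyphenyl on a carbon with a double bond to nitrogen gives a clear step (a 5.0-fold higher number from compound 3 to compound 4 (0.70 log units; beyond the scatter)). The other two comparisons show no shift (no change at the digits printed from compound 2 to compound 4 (within the scatter); no change at the digits printed from compound 1 to compound 4 (within the scatter)), so compound 3 alone stands apart among the four compounds. Nothing available accounts for the difference between the two hydroxyphenyl groups.

Still open, going by these compounds, is whether an amine or a carboxylic acid in place of the hydroxy group of compound 3 would give a number like that of compound 3 or like that of compound 4.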